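This account rests on a few compounds, and the source may have more. Where it says the series, first, only, none or still open, it means among the compounds named here.

In an ADME assay on Vero cells (Chlorocebus sabaeus) for cytotoxicity, read by crystal violet staining (a lower number here means that less compound is tolerated, a higher number that more compound is tolerated), compound 1 (`CN(/N=N/c1ccccc1)c1ccccc1`) gives 50000 nM while compound 2 (`CN(C)CCCN(/N=N/c1cccc([N+](=O)[O-])c1)c1ccccc1`) gives 40000 nM and compound 3 (`CN(C)CCCN(/N=N/c1ccccc1)c1cccc(C(F)(F)F)c1`) gives 20000 nM on the same scale. Compound 3 lies within the scatter of compound 2 and beyond the scatter below compound 1. Compound 4 (`CN(C)CCCN(/N=N/c1ccccc1)c1ccccc1`) has hydrogen in place of trifluoromethyl on an aromatic carbon and is otherwise the same as compound 3. Within the data shown here, no measured pair isolates this change, and the three numbers lie close together. No step beyond the scatter is therefore expected in this assay, with a slight lean towards a higher number. The estimate is a 1.5-fold higher number from compound 3 to compound 4 (0.18 log units; within the scatter) in this series. For compound 4 the estimated value is 30000 nM with an expected range from 13000 nM to 70000 nM in this measurement.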

Compound 4, half-maximal cytotoxic concentration: 35000 nM
The estimate for compound 4 lay 1.2-fold (0.07 log units) below the measured number; the measured number falls inside the stated range.
By their numbers in this assay, from the lowest: compounds 3, 4, 2 and 1 (each within the scatter of the next, the first and the last beyond it).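

In this assay, the aromatic carbon carries hydrogen or trifluoromethyl without a step beyond the scatter (a 1.8-fold higher number from compound 3 to compound 4 (0.24 log units; within the scatter)), and hydrogen in place of nitro also stays within it (a 1.1-fold lower number from compound 2 to compound 4 (0.06 log units; within the scatter)). On the saturated chain carbon, 2-(dimethylamino)ethyl in place of hydrogen likewise stays within the scatter (a 1.4-fold lower number from compound 1 to compound 4 (0.15 log units; within the scatter)). No measurement at hand explains these steps.

As far as these compounds go, whether an amine or a carboxylic acid on this aromatic carbon would also stay within the scatter remains open. So does the effect of a longer chain in place of 2-(dimethylamino)ethyl.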